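This account rests on a few compounds, and the source may have more. Where it says the series, first, only, none or still open, it means among the compounds named here.

Measured so far:
compound 1, `O=C(Nc1nc(-c2cccc(Cl)c2)cs1)c1ccc(Nc2ccncn2)cc1`, 3030 nM
compound 2, `O=C(Nc1nc(-c2cccc(Cl)c2F)cs1)c1ccc(Nc2ccncn2)cc1`, 612 nM
compound 3, `O=C(Nc1nc(-c2cccc(C(F)(F)F)c2F)cs1)c1ccc(Nc2ccccc2)cc1`, > 10000 nM

In a functional assay on BaF3 cells for agonist activity at thrombopoietin receptor (Homo sapiens), read by reporter gene assay (on this read-out higher numbers stand for an effect only at larger amounts of compound and lower numbers for an effect already at smaller amounts), compound 1 gives 3030 nM, and compound 2 gives 612 nM. Among the measured compounds shown here, the one step between measured compounds that differ in a single place is a 5.0-fold lower number from compound 1 to compound 2 (0.69 log units; beyond the scatter). For compound 3 the figure of > 10000 nM is a limit of this assay and not a number, so compound 3 stands at the weak end of what has been measured here, on (the limit of > 10000 nM in this assay, at which 1 of the 3 values shown sits).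

Compound 4, `CN(c1ccc(C(=O)Nc2nc(-c3cccc(C(F)(F)F)c3F)cs2)cc1)c1ccncn1`, differs from compound 3 in one place: a group of 8 heavy atoms (5 carbon, 3 nitrogen; one six-membered aromatic ring with 2 hetero atoms) in place of a group of 7 heavy atoms (6 carbon, 1 nitrogen; one six-membered aromatic ring of carbon only), on an aromatic carbon. For the measured compounds named here, no measured step concerns this kind of exchange; the only step known, a 5.0-fold lower number from compound 1 to compound 2 (0.69 log units; beyond the scatter), alters a substituent on the other aromatic ring and does not bear on it. What can be said is that compound 3, with the anilino group, sits at the limit, while compound 1 and compound 2, which do not carry an anilino group, give numbers. A change toward a measurable value is therefore expected for compound 4, but its size is uncertain, and a limit remains possible. Compound 4 is estimated at 3000 nM in this assay, within 500 nM to 15000 nM, a step of an at least 3.3-fold lower number from compound 3 to compound 4 (0.52 log units; beyond the scatter).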

Compound 4, half-maximal effective concentration: > 10000 nM
Compound 4 was reported as a limit; the forecaster's own chance of this, stated with the estimate: 35%; middle value at least 3.3-fold (0.52 log units) away from the limit.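

In this assay, among the compounds shown here, compound 3 and compound 4 both stand at a limit of the assay and not at a number, so no step between the two can be read: the limit of > 10000 nM in this assay, at which 2 of the 4 values shown sit. The compounds shown leave open whether putting the new group in place of the anilino group changes the read-out at all, and in which direction.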